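The compounds below may be only part of what the source reports. "The series", "measured", "known", "first", "only" and "open" are said of these compounds alone.

Measured so far:
compound 1, `Nc1nc(Cl)c2ncn(Cc3ccccc3CCl)c2n1`: 75900 nM
compound 2, `ClCc1cccc(Cn2cnc3nc(Cl)nc(Cl)c32)c1`: 4780 nM

Both numbers come from a functional assay on ACHN cells (Homo sapiens) for cytotoxicity, read by sulforhodamine B assay, with a stated time of 48 h; a lower number here means that less compound is tolerated, a higher number that more compound is tolerated. Compound 1 gives the higher of the two values, 75900 nM, meaning that more of it is tolerated by the cells; compound 2 gives 4780 nM, and the gap between the two lies beyond the usual scatter of this kind of measurement. So compound 1 stands at the top of the small set.

The unmeasured compound 3, `ClCc1ccccc1Cn1cnc2c(Cl)ncnc21`, is compound 1 with one change: hydrogen in place of amino on an aromatic carbon. Within the data shown here, no pair of measured compounds differs by this change alone, so there is no directly comparable step. Compound 2 also lacks the amino group, but it differs from compound 1 in other places too, so its lower number is only a loose hint. Taken with that hint, the step from compound 1 to compound 3 is expected to run toward a lower number, modest in size and probably at or somewhat beyond the scatter, as a 2.5-fold lower number from compound 1 to compound 3 (0.40 log units; beyond the scatter). Compound 3 is therefore estimated at 30000 nM in this assay, within a range of 8000 nM to 100000 nM.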

Compound 3, concentration lethal to 50% of the cells: 26900 nM
Beside the measured number, compound 3's estimate is 1.1-fold (0.05 log units) above it; measured number inside the range.
By their numbers in this assay, from the lowest: compound 2; then compound 3; then compound 1.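

In this assay, among these compounds, the pair of compound 1 and compound 3 gives the first comparison in which only one place changes: hydrogen replaces amino on the aromatic carbon between two ring nitrogen atoms, and the result is (a 2.8-fold lower number from compound 1 to compound 3 (0.45 log units; beyond the scatter)). The step is modest, but it lies beyond the scatter, so the amino group at this position does make a measurable difference to how much compound these cells tolerate, with less of the compound lacking it being tolerated. No measurement shown here accounts for this shift, so the pair records the size and direction of the change without explaining it.

This single exchange does not show whether the amino group is unusual at this carbon, since a methylamino group, a hydroxyl group or a methoxy group in the same place could give a number near either compound 1 or compound 3. On these data alone, it also remains open whether the same exchange would produce a similar step in a compound with the chloromethyl group elsewhere on its benzene ring, or with a different group in place of the chloro group on the shared core.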